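This account rests on a few compounds, and the source may have more. Where it says the series, first, only, none or still open, it means among the compounds named here.

In a functional assay on CCRF-CEM cells (Homo sapiens) for cytotoxicity, read by MTT assay, with a stated time of 72 h (on this read-out lower numbers stand for stronger inhibition of growth and higher numbers for weaker inhibition of growth), compound 1 `N#C[Se]c1ccc(NC(=O)Oc2ccc(F)cc2)cc1` gives 12600 nM, the highest of the three numbers, although compound 3 `CCOC(=O)Nc1ccc([Se]C#N)cc1` at 9800 nM and compound 2 `C=CCOC(=O)Nc1ccc([Se]C#N)cc1` at 9200 nM both lie within the scatter of that figure. Among the compounds with values here, the only step between two measured compounds, a 1.1-fold higher number from compound 2 to compound 3 (0.03 log units; within the scatter), concerns the saturated chain carbon bound to an oxygen next to a carbonyl group, a different part of the molecule. Compound 4 `Cc1ccc(OC(=O)Nc2ccc([Se]C#N)cc2)cc1` differs from compound 1 by methyl in place of fluoro on an aromatic carbon. Within the data shown here, no measured step bears on this exchange, so compound 4 is expected to stay close to compound 1, and no change at the digits printed from compound 1 to compound 4 (within the scatter) is expected to remain within the scatter. Compound 4 is accordingly estimated at 12600 nM, with a range from 6000 nM to 26000 nM.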

Compound 4, concentration for 50% growth inhibition: 17400 nM
For compound 4 the middle estimate is 1.4-fold (0.14 log units) below the measured one; the measured number falls inside the stated range.
By their numbers in this assay, from the lowest: compounds 2, 3, 1 and 4 (each within the scatter of the next).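

Within the data shown here, this is the first step read at the aromatic carbon para to a large group, where the earlier compounds offered no comparison. In this assay, methyl in place of fluoro gives a 1.4-fold higher number from compound 1 to compound 4 (0.14 log units; within the scatter), so this assay does not separate these two groups at this position. Nothing measured here bears on why the result falls as it does. Going by these compounds, it remains open whether an amine, a carboxylic acid or a methoxy group on this carbon would shift the number beyond the scatter, and whether methyl and fluoro would also stay this close elsewhere on the ring.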